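A few compounds are considered here, and "the series" means these few. Any claim that something is new, unique, unknown or untested is made for them only; others in the source may bear on it.

Compound 1 `CCOC(=O)c1c(-c2ccc(Cl)cc2)cc(-c2ccccc2)nc1N1CCCCC1` gives 29.1%; compound 2 `CCOC(=O)c1c(-c2ccc(Cl)c(Cl)c2)cc(-c2ccccc2)nc1N1CCCCC1` gives 67.9%.

For the measured compounds named here, in a functional assay on the whole organism (strain Wister albino) for inhibition, with Rattus norvegicus as the target, read by paw edema, with stated times of 1 h and 2 h, at a dose of 50 mg/kg by the intraperitoneal route (a lower number here means less inhibition, a higher number more inhibition at the dose given (going by the name of the read-out)), compound 1 stands lowest of the two numbers, and the only measured step, a number 38.8 percentage points higher from compound 1 to compound 2 (beyond the scatter), concerns chloro in place of hydrogen on an aromatic carbon. Compound 3 `CCOC(=O)c1c(-c2ccc(Cl)cc2)cc(-c2ccccc2)nc1N1CCN(C)CC1` differs from compound 1 otherwise: 4-methylpiperazin-1-yl in place of piperidin-1-yl on an aromatic carbon. Going by the values given here, no measured step bears on a change at this place, so the account has nothing to set the size of the step, and no shift beyond the scatter is expected. Compound 3 is therefore estimated at 30%, between 15% and 50%, which is expected to mean a number 0.9 percentage points higher from compound 1 to compound 3 (within the scatter).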

Compound 3, a percentage reported as inhibition, in the whole organism at one dose (the size of the read-out at that dose, not a potency): 39.6%
Compound 3: middle estimate off by 9.6 percentage points, on the low side; low and high end bracket the measured number.
By their numbers in this assay, from the lowest: compound 1; then compound 3; then compound 2.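

In this assay, putting 4-methylpiperazin-1-yl in place of piperidin-1-yl gives a number 10.5 percentage points higher from compound 1 to compound 3 (beyond the scatter). For the compounds shown here, this shows for the first time that the group on the aromatic carbon next to the ring nitrogen, and not only the chloro substitution on the aryl ring, can move the read-out. Nothing available explains this step.

As far as these compounds go, whether a morpholin-4-yl ring or an open-chain dimethylamino group at this place would give a similar number remains open. So does whether the second chloro would add as much alongside 4-methylpiperazin-1-yl.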